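Compound 4: methyl on the pyrazole ring nitrogen

This account rests on a few compounds, and the source may have more. Where it says the series, first, only, none or still open, it means among the compounds named here.

Of the compounds shown here, three of the shared core have been measured in an assay on microsomes from intestine for inhibition of acyl-CoA:cholesterol acyltransferase (Oryctolagus cuniculus); a higher number here means a weaker inhibitor, a lower number a stronger inhibitor. Compound 1 `Cc1cc(C)c(NC(=O)N(Cc2cccc(-c3nnn(C)n3)c2)C2CCCCCC2)c(C)c1` gives 100 nM, compound 2 `Cc1cc(C)c(NC(=O)N(Cc2cccc(-n3cccc3)c2)C2CCCCCC2)c(C)c1` gives 20 nM, and compound 3 `Cc1cc(C)c(NC(=O)N(Cc2cccc(-c3cn[nH]c3)c2)C2CCCCCC2)c(C)c1` gives 38 nM. Compound 3 stands second highest of the three: a 2.6-fold lower number from compound 1 to compound 3 (0.42 log units; beyond the scatter), while a 1.9-fold higher number from compound 2 to compound 3 (0.28 log units; within the scatter). Compound 4 `Cc1cc(C)c(NC(=O)N(Cc2cccc(-c3cnn(C)c3)c2)C2CCCCCC2)c(C)c1` differs from compound 3 by methyl in place of hydrogen on an aromatic nitrogen. Among the measured compounds shown here, no measured step alters a substituent on the five-membered ring itself; a 5.0-fold lower number from compound 1 to compound 2 (0.70 log units; beyond the scatter) and the other two steps each exchange one whole ring for another, so none bears directly on this change. In this assay no step beyond the scatter is therefore expected: a 1.1-fold higher number from compound 3 to compound 4 (0.02 log units; within the scatter). Compound 4 is estimated at 40 nM, with a range of 18 nM to 90 nM.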

Compound 4, half-maximal inhibitory concentration: 44 nM
Compound 4: the middle estimate sits 1.1-fold (0.04 log units) below what was measured; measured number inside the range.
By their numbers in this assay, from the lowest: compounds 2, 3 and 4 (each within the scatter of the next, the first and the last beyond it); then compound 1.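

In this assay, methyl in place of hydrogen on the aromatic nitrogen leaves the number within the scatter: a 1.2-fold higher number from compound 3 to compound 4 (0.06 log units; within the scatter), so in this pair the hydrogen on that nitrogen is not required for inhibition. The methylated ring also stays apart from both other rings: a 2.2-fold higher number from compound 2 to compound 4 (0.34 log units; beyond the scatter), and a 2.3-fold lower number from compound 1 to compound 4 (0.36 log units; beyond the scatter). No evidence is available on why the methyl step is this small. From the compounds shown here alone, whether an ethyl group, a longer chain or a chain ending in an amine on the same nitrogen would keep the number at this level stays open.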